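A few compounds are considered here, and "the series" means these few. Any claim that something is new, unique, unknown or untested is made for them only; others in the source may bear on it.

In an ADME assay on LLC-PK1 cells (Sus scrofa) for permeability, with a stated time of 3 h, tested at 1 uM (a lower number here means that the compound crosses the layer more slowly, a higher number that the compound crosses the layer faster), compound 1 `O=C(O)CNC(=O)c1c(O)c2ccc(Cl)cc2n(Cc2ccc(C(F)(F)F)cc2)c1=O` gives 16 10^-6 cm/s as its reading, whereas compound 2 `O=C(O)CNC(=O)c1c(O)c2c(n(Cc3ccc(C(F)(F)F)cc3)c1=O)CCOC2` gives 4 10^-6 cm/s and so holds the lower of the two numbers, with a gap beyond the usual scatter of the measurement. These two compounds do not form a comparison at one place, so the gap cannot be tied to a single change.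

Compound 3 `O=C(O)CNC(=O)c1c(O)c2c(n(Cc3ccc(Cl)cc3)c1=O)CCOC2` has not yet been measured. It departs from compound 2 at one site, on an aromatic carbon of a six-membered aromatic ring of carbon only, para to a large group, where chloro stands in place of trifluoromethyl: chloro in place of trifluoromethyl on an aromatic carbon (the 4-(trifluoromethyl)phenyl becomes 4-chlorophenyl).

Among the compounds with values here, no measured pair here shows this exchange, so the expectation starts from compound 2 with its 4 10^-6 cm/s as the only anchor. No shift beyond the scatter is expected in this assay and the estimated change is no change at the digits printed from compound 2 to compound 3 (within the scatter) in size. For compound 3 the estimated value is 4 10^-6 cm/s with an expected range from 2 10^-6 cm/s to 8 10^-6 cm/s in repeated measurements.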

Compound 3, apparent permeability: 3.6 10^-6 cm/s
For compound 3 the middle estimate is 1.1-fold (0.05 log units) above the measured one; low and high end bracket the measured number.
By their numbers in this assay, from the lowest: compounds 3 and 2 (each within the scatter of the next); then compound 1.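

In this assay, within the data shown here, chloro in place of trifluoromethyl, on an aromatic carbon of a six-membered aromatic ring of carbon only and para to a large group, gives a 1.1-fold lower number from compound 2 to compound 3 (0.05 log units; within the scatter), and this is the only comparison here that can be tied to a single site. At this position on the core shared by compound 2 and compound 3, the two groups cannot be told apart by this read-out, even though a group of 4 heavy atoms gives way to one of a single heavy atom. Nothing measured alongside these numbers accounts for this result.

Still open, from the compounds shown here alone, is whether a group of another kind at this place, such as an amine or a nitrile, would also leave the number within the scatter, and whether the same exchange would read alike on the core of compound 1 , which gives 16 10^-6 cm/s in this assay. Also open, going by these compounds, is how the number would respond if a primary amide took the place of the carboxylic acid that all three compounds carry.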